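A few compounds are considered here, and "the series" means these few. Any claim that something is new, unique, unknown or untested is made for them only; others in the source may bear on it.

Compound 1 `CC(C)(C)c1ccc(-c2nnc(SCCCN3CCN(c4ccccc4)CC3)[nH]2)cc1` is one of the two measured compounds. In a functional assay on COLO 205 cells (Homo sapiens) for cytotoxicity, read by MTT assay, with a stated time of 24 h (on this read-out higher numbers stand for weaker inhibition and lower numbers for stronger inhibition), compound 1 gives only a limit, > 300000 nM. Compound 2 `Cc1cccc(-c2nnc(SCCCN3CCN(c4ccccc4)CC3)[nH]2)c1` likewise gives only a limit in this assay, > 300000 nM. The step that the two limits leave unreadable from compound 1 to compound 2 cannot be read, since both values sit at the limit of > 300000 nM in this assay, at which 2 of the 2 values shown sit. Compound 3 `Cc1cccc(-c2nnc(SCCCN3CCN(c4ccccn4)CC3)[nH]2)c1` differs from compound 2 by pyridin-2-yl in place of phenyl on an amine nitrogen in a ring. Among the measured compounds shown here, no measured step touches this ring, and the single known step has no readable size, so no shift beyond the scatter is expected, and compound 3 is expected to stay near the limit. Compound 3 is estimated at 400000 nM, within 100000 nM to 1500000 nM, an expected step that the limit leaves unreadable from compound 2 to compound 3.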

Compound 3, half-maximal inhibitory concentration: > 300000 nM
Compound 3 was reported as a limit; the forecaster's own chance of this, stated with the estimate: 80%; the middle value does not contradict the limit.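

Among the compounds shown here, compound 3, like compound 2, gives only a limit in this assay and so no step between them can be read: the limit of > 300000 nM in this assay, at which 3 of the 3 values shown sit. These compounds leave open which change to the shared core, if any, would bring measurable cytotoxicity.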